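The compounds below may be only part of what the source reports. "The series", "measured", "known", "first", "only" and "open" are said of these compounds alone.

Of the compounds shown here, three sharing one core have been tested in a functional assay on K562 cells (Homo sapiens) for antiproliferative activity, with a stated time of 72 h; on this read-out higher numbers stand for weaker inhibition and lower numbers for stronger inhibition. Compound 1 `OC[C@H]1O[C@@H](n2cnc3c(NCc4ccccc4Br)ncnc32)[C@H](O)[C@@H]1O`, which carries a 2-bromophenyl group, gives 10000 nM. Compound 2 `COc1cccc(CNc2ncnc3c2ncn3[C@@H]2O[C@H](CO)[C@@H](O)[C@H]2O)c1` returns only a limit of the assay, > 166000 nM. Compound 3 `OC[C@H]1O[C@@H](n2cnc3c(NCc4cc(F)cc(F)c4)ncnc32)C(O)C1O` likewise returns only a limit, > 166000 nM. Among the measured compounds shown here, the single step between compounds that differ in one place, an at least 16-fold higher number from compound 1 to compound 2 (1.22 log units; beyond the scatter), shows that exchanging the aryl group already pushed the reading past what the method can report; indeed (the limit of > 166000 nM in this assay, at which 2 of the 3 values shown sit). Compound 2 therefore stands at the weak end of the numbers shown, with no finite value of its own.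

Compound 4 `COc1cccc(CNc2ncnc3c2ncn3[C@@H]2O[C@H](CO)[C@@H](O)[C@H]2O)c1O` differs from compound 2 by hydroxy in place of hydrogen on an aromatic carbon. For the measured compounds named here, no measured step tests the addition of a hydroxy group, and the one measured step concerns a different change, so it offers no direction for this one. The expected step of a number no higher from compound 2 to compound 4 (the limit leaves the size open) is accordingly none beyond the scatter, and a reading at the limit once more is the most likely outcome. Compound 4 is expected at about 166000 nM, within 60000 nM to 500000 nM.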

Compound 4, half-maximal inhibitory concentration: 27900 nM
Compound 4: the middle estimate sits 5.9-fold (0.77 log units) above what was measured, and the stated range ends above it.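

Adding one hydroxy group on the aromatic ring, ortho to a large group and ortho to a methoxy group, brings back a finite reading, with an at least 5.9-fold lower number from compound 2 to compound 4 (0.77 log units; beyond the scatter). Among the compounds shown here, this place on the 3-methoxyphenyl ring therefore responds to a change, something the earlier compounds could not show while two of them ended at a limit. The 2-hydroxy-3-methoxyphenyl group still falls short of the 2-bromophenyl group, with a 2.8-fold higher number from compound 1 to compound 4 (0.45 log units; beyond the scatter), so the hydroxy group recovers only part of the loss.

On these data alone, the true size of the gain stays open, because compound 2 has a limit and no finite value of its own: the limit of > 166000 nM in this assay, at which 2 of the 4 values shown sit. The compounds shown also do not tell whether an amine or a methyl group in the same place would bring a similar gain.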